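The source may hold more compounds than are shown below. What is called first, only, known or untested is meant among the compounds shown, and "the series" means these compounds.

In an assay on CHO cells for displacement of a labelled ligand from Substance-P receptor (Homo sapiens), with a stated time of 90 min (on this read-out higher numbers stand for weaker inhibition and lower numbers for stronger inhibition), compound 1, `Cc1nc(Cl)cc(-c2ccccc2)c1C(=O)NCc1cc(C(F)(F)F)cc(C(F)(F)F)c1`, gives 270 nM. Compound 2, `Cc1nc(Cl)cc(-c2ccccc2)c1C(=O)N(C)Cc1cc(C(F)(F)F)cc(C(F)(F)F)c1`, differs from it in one place, (methyl in place of hydrogen on an amide-type nitrogen), and gives 91 nM; that single change made the step of a 3.0-fold lower number from compound 1 to compound 2 (0.47 log units; beyond the scatter). Compound 3, `Cc1cc(-c2ccccc2)c(C(=O)NCc2cc(C(F)(F)F)cc(C(F)(F)F)c2)c(C)n1`, rests on a different core: it differs from compound 1 by methyl in place of chloro on an aromatic carbon, and compound 3 gives 434 nM, a step of a 1.6-fold higher number from compound 1 to compound 3 (0.21 log units; within the scatter). Compound 4, `Cc1cc(-c2ccccc2)c(C(=O)N(C)Cc2cc(C(F)(F)F)cc(C(F)(F)F)c2)c(C)n1`, is not yet measured. It stands to compound 3 as compound 2 stands to compound 1: the change is methyl in place of hydrogen on an amide-type nitrogen, at a place described in the same words in both pairs, so it is the same change. This change has been measured only once, so the expectation rests on that one step. In this assay compound 4 is expected to make a step of a 3.0-fold lower number from compound 3 to compound 4 (0.48 log units; beyond the scatter), matching the earlier one. Compound 4 is estimated at 145 nM, most likely between 70 nM and 300 nM.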

Compound 4, half-maximal inhibitory concentration: 41 nM
Compound 4: the middle estimate sits 3.5-fold (0.55 log units) above what was measured, outside the stated range (below it).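

Methyl in place of hydrogen on an amide-type nitrogen lowers the number on both cores, but the size of the step does not carry over. In this assay the new step is an 11-fold lower number from compound 3 to compound 4 (1.02 log units; beyond the scatter) and differs from the earlier one: the same change on two cores in this assay, a 3.0-fold lower number (0.47 log units; beyond the scatter) from compound 1 to compound 2 and an 11-fold lower number (1.02 log units; beyond the scatter) from compound 3 to compound 4, 3.6-fold (0.55 log units) apart, beyond the scatter of two such steps. Methyl in place of chloro on an aromatic carbon also depends on its surroundings, giving a 2.2-fold lower number from compound 2 to compound 4 (0.35 log units; beyond the scatter) when the amide-type nitrogen bears methyl: the same change on two cores in this assay, a 1.6-fold higher number (0.21 log units; within the scatter) from compound 1 to compound 3 and a 2.2-fold lower number (0.35 log units; beyond the scatter) from compound 2 to compound 4, 3.6-fold (0.55 log units) apart, beyond the scatter of two such steps. These four compounds show that the two changes do not add up independently, but they do not show why, or whether this holds on any other core.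

As far as these compounds go, it remains open whether an ethyl group on that nitrogen would behave like methyl. From the compounds shown here alone, it is also open how an amine or a methoxy group in place of chloro would behave.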